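From Fluoro to Chloro: Expecting Compound 3

The source may report more compounds than this note shows. Statements on the series, on what has been measured and on what is new or still open speak of the compounds shown alone.

Of the compounds shown here, two have so far been measured in a functional assay on TK-10 cells (Homo sapiens) for inhibition, read by sulforhodamine B assay, with a stated time of 48 h; on this read-out higher numbers stand for weaker inhibition of growth and lower numbers for stronger inhibition of growth. Compound 1 `N=C(N)c1ccc(-c2ccc(-c3cncc4ccccc34)s2)s1` gives 1840 nM in this assay. Compound 2 `N=C(N)c1ccc(-c2ccc(-c3ccc(F)cc3)o2)o1` gives 1550 nM in this assay, a number sitting beside that of compound 1 within the usual scatter, so neither can be called the stronger inhibitor. Compound 3 `N=C(N)c1ccc(-c2ccc(-c3ccc(Cl)cc3)o2)o1` differs from compound 2 in one place: chloro in place of fluoro on an aromatic carbon. Among the measured compounds shown here, no measured pair yet shows what this swap does, so only a small step in this assay is expected, leaning toward stronger inhibition of growth or none beyond the scatter. Compound 3 is therefore estimated at 1200 nM, ranging from 500 nM to 3000 nM. The expected step is a 1.3-fold lower number from compound 2 to compound 3 (0.11 log units; within the scatter).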

Compound 3, concentration for 50% growth inhibition: 2070 nM
Compound 3: middle estimate off by 1.7-fold (0.24 log units), on the low side; low and high end bracket the measured number.
By their numbers in this assay, from the lowest: compounds 2, 1 and 3 (each within the scatter of the next).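

Among the compounds shown here, the first measured pair at this position gives a 1.3-fold higher number from compound 2 to compound 3 (0.13 log units; within the scatter) in this assay for chloro in place of fluoro on an aromatic carbon, para to a large group. At this position, the two halogens therefore cannot be told apart on this read-out. Nothing at hand explains the result or shows how either group acts here.

The compounds shown leave open whether this tolerance extends beyond these two halogens. An amine, a methoxy group or a carboxylic acid at the same place could give a step beyond the scatter, and only such a compound would show how sensitive this position is.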